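This account rests on a few compounds, and the source may have more. Where it says the series, first, only, none or still open, it means among the compounds named here.

Three sulfonamides built on a shared core were tested in an assay on cells for inhibition of HSP60/HSP10 (Homo sapiens), with a stated time of 60 min; on this read-out higher numbers stand for weaker inhibition and lower numbers for stronger inhibition. Compound 1 `COc1ccc(Cl)cc1S(=O)(=O)Nc1ccc(-c2nc3ccccc3o2)cc1` reaches only the limit of the assay, giving > 100000 nM. Compound 2 `Cc1cccc(S(=O)(=O)Nc2ccc(-c3nc4ccccc4o3)cc2)c1` likewise gives only the limit > 100000 nM in this assay. Compound 3 `O=S(=O)(Nc1ccc(-c2nc3ccccc3o2)cc1)c1ccccc1Cl`, the starting point here, also stops at the limit, > 100000 nM, in this assay. The steps among them, a step that the two limits leave unreadable from compound 1 to compound 2, a step that the two limits leave unreadable from compound 1 to compound 3 and a step that the two limits leave unreadable from compound 2 to compound 3, are unreadable because the limit of > 100000 nM in this assay, at which 3 of the 3 values shown sit, holds all three values. Compound 3 therefore stands at the limit alongside the other two, with no number of its own. Compound 4 `COc1cccc(S(=O)(=O)Nc2ccc(-c3nc4ccccc4o3)cc2)c1` differs from compound 3 in one place (3-methoxyphenyl in place of 2-chlorophenyl on a sulfonyl sulfur). For the measured compounds named here, none of the measured steps gives a readable size, so no step beyond the scatter can be expected in either direction. The expected change in this assay is a step that the limit leaves unreadable from compound 3 to compound 4. Compound 4 is accordingly expected to give about 150000 nM in this assay, within a range from 50000 nM to 500000 nM, most likely again only as a limit.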

Compound 4, half-maximal inhibitory concentration: 80000 nM
Estimate against measurement, compound 4: 1.9-fold (0.27 log units) above; the measured number falls inside the stated range.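

For the compounds shown here, at this place on the sulfonyl sulfur, 3-methoxyphenyl gives the first real number in this assay rather than a limit, so this compound offers a measured reference point for the series. The comparisons read as an at least 1.2-fold lower number from compound 3 to compound 4 (0.09 log units; that floor lies within the scatter) and an at least 1.2-fold lower number from compound 2 to compound 4 (0.09 log units; that floor lies within the scatter) and an at least 1.2-fold lower number from compound 1 to compound 4 (0.09 log units; that floor lies within the scatter) and each of these floors lies within the usual scatter, so no true gain from the change is established. Each step is only a floor because the compound it starts from has no number of its own: the limit of > 100000 nM in this assay, at which 3 of the 4 values shown sit.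

Going by these compounds, how large these steps really are stays open, since the true values behind the limits are unknown. Also open, on these data alone, is whether an amine, a carboxylic acid or a longer chain such as ethoxy in place of methoxy would move the number beyond the scatter.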